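Gem-Dimethyl Branching on the Alkyne Chain of Compound 1

The source may report more compounds than this note shows. Statements on the series, on what has been measured and on what is new or still open speak of the compounds shown alone.

Compound 1 `COCCC#Cc1c(Cl)c2c(Cl)cc(C(N)=O)nc2n1[C@H]1CCCNC1` holds the lower of the two values shown in a functional assay on KG-1 cells (Homo sapiens) for antiproliferative activity; a higher number here means that more compound is needed for the effect, a lower number that less compound is needed: in this assay compound 1 gives 39 nM. Compound 2 `NC(=O)c1cc(Cl)c2c(Cl)c(C#CC3CNCCO3)n([C@H]3CCCNC3)c2n1` has been measured more than once, and in this assay compound 2 gives 365 nM; 197 nM (2 entries); the spread between its repeats is seen in the several entries of compound 2 in this assay, 365 nM; 197 nM (2 entries) and gives a sense of how far single readings can wander.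

Compound 3 `COC(C)(C)CC#Cc1c(Cl)c2c(Cl)cc(C(N)=O)nc2n1[C@H]1CCCNC1` is the untested partner of compound 1. The change is 1-methoxy-1-methylethyl in place of methoxymethyl on a saturated chain carbon bound to a triple-bonded carbon. Among the compounds with values here, no pair of measured compounds shows this kind of change, so the size of the step rests on expectation alone. He expects a small step, if any, with a slight drift toward a higher number, not clearly beyond the scatter: the expected step is a 1.4-fold higher number from compound 1 to compound 3 (0.15 log units; within the scatter). For compound 3 in this assay he estimates 55 nM, with a range from 20 nM to 160 nM.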

Compound 3, half-maximal effective concentration in the KG-1 assay: 172 nM
The estimate for compound 3 lay 3.1-fold (0.50 log units) below the measured number, and the stated range ends below it.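

Within the data shown here, until now no measured pair spoke to this position; here the chain proves sensitive to added branching. In the KG-1 assay the change to 1-methoxy-1-methylethyl gives a 4.4-fold higher number from compound 1 to compound 3 (0.64 log units; beyond the scatter). That step is wider than the spread between repeats of compound 2, the only repeats shown: the several entries of compound 2 in the KG-1 assay, 365 nM; 197 nM (2 entries) In a physicochemical assay for solubility, measured as thermodynamic solubility, at pH 7.4 (a lower number here means a less soluble compound, a higher number a more soluble compound), compound 1 gives 86000 nM and compound 3 gives 1200 nM. The same change carries a far larger penalty in the physicochemical assay, so on this pair the cost falls more heavily on solubility than on antiproliferative activity: the measured solubility of compound 1, 86000 nM, and of compound 3, 1200 nM, a 72-fold lower number (1.86 log units; beyond the scatter)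

What the compounds shown leave open is whether a single methyl branch on the same chain would retain the KG-1 assay result of compound 1. Nor do they show how a hydroxyl or an amine in place of the methoxy group would behave in the KG-1 assay or in the physicochemical assay.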